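The compounds below may be only part of what the source reports. "The series", "measured", "known", "first", "only" and "open" are said of these compounds alone.

For the measured compounds named here, compound 2 `C#CCSC[C@H](NC(=O)c1cc(O)c(O)c(O)c1)C(=O)OC` is one of only two compounds measured in an assay on RAW264.7 cells for antagonist activity at Toll-like receptor 2 (Mus musculus), read by Griess assay, with a stated time of 24 h; on this read-out higher numbers stand for weaker inhibition and lower numbers for stronger inhibition. In this assay compound 2 gives 71500 nM, while compound 1 `C=CCCSC[C@H](NC(=O)c1cc(O)c(O)c(O)c1)C(=O)OC` gives 57800 nM; the step of a 1.2-fold higher number from compound 1 to compound 2 (0.09 log units; within the scatter) lies within the scatter, so the two numbers stand together rather than apart. Compound 3 `COC(=O)[C@H](CSCc1ccccc1)NC(=O)c1cc(O)c(O)c(O)c1` has not yet been measured. It differs from compound 2 by phenyl in place of ethynyl on a saturated chain carbon bound to a sulfur. Going by the values given here, only one measured step bears on this change, a 1.2-fold higher number from compound 1 to compound 2 (0.09 log units; within the scatter), which swapped one short unsaturated chain for another on that same carbon and left the number within the scatter. Among the compounds with values here, no measured step replaces a chain with an aromatic ring, so the weight of the phenyl itself is untested. The expected step is therefore a 1.3-fold lower number from compound 2 to compound 3 (0.11 log units; within the scatter), with little reason to look for a shift beyond the scatter. Compound 3 is estimated at 55000 nM, within a range from 18000 nM to 170000 nM.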

Compound 3, half-maximal inhibitory concentration: 60700 nM
Estimate against measurement, compound 3: 1.1-fold (0.04 log units) below; low and high end bracket the measured number.
By their numbers in this assay, from the lowest: compounds 1, 3 and 2 (each within the scatter of the next).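

In this assay, the place on a saturated chain carbon bound to a sulfur now carries an aromatic ring as well as short unsaturated chains: phenyl in place of ethynyl gives a 1.2-fold lower number from compound 2 to compound 3 (0.07 log units; within the scatter), and phenyl in place of allyl gives a 1.1-fold higher number from compound 1 to compound 3 (0.02 log units; within the scatter). Both steps lie within the scatter, so even a phenyl of 6 heavy atoms and one six-membered aromatic ring, entering where ethynyl had 2 heavy atoms and no ring, leaves the numbers standing together, something the earlier pair could not show. No supporting data are available to explain this result.

As far as these compounds go, all three groups here are made of carbon and hydrogen only, so it remains open how an amine, a carboxylic acid or a longer chain in this place would read. From the compounds shown here alone, the effect of changes elsewhere on the shared core also remains open.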